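Removing the chlorine from a benzyl group: cytotoxicity outlook

The source may report more compounds than this note shows. Statements on the series, on what has been measured and on what is new or still open speak of the compounds shown alone.

Measured so far in an ADME assay on Huh-7 cells (Homo sapiens) for cytotoxicity, with a stated time of 72 h; on this read-out lower numbers stand for higher toxicity in this test and higher numbers for lower toxicity in this test:
- compound 1 `CS(=O)(=O)Nc1ccc2c(c1)S(=O)(=O)N=C(C1=C(O)C3CCCC3N(Cc3ccc(Cl)cc3)C1=O)N2`, which gives > 10000 nM, a limit of the test rather than a number.
- compound 2 `CS(=O)(=O)Nc1ccc2c(c1)S(=O)(=O)N=C(C1=C(O)[C@H]3CCC[C@H]3N(Cc3ccc(F)c(Cl)c3)C1=O)N2`, which gives > 1000 nM, again a limit rather than a number.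
- compound 3 `CS(=O)(=O)Nc1ccc2c(c1)S(=O)(=O)N=C(C1=C(O)C3CCCCC3N(C3CCCCC3)C1=O)N2`, which gives > 33000 nM, also a limit rather than a number.

All three measured compounds share the same core and differ only in the groups attached to it. None of them produced a number on this assay; each sits at one of the reporting limits, the limit of > 10000 nM in this assay, at which 1 of the 3 values shown sits, for compound 1, the limit of > 1000 nM in this assay, at which 1 of the 3 values shown sits, for compound 2 and the limit of > 33000 nM in this assay, at which 1 of the 3 values shown sits, for compound 3. So compound 1 stands where a limit is known but no measured toxicity, and no single-change step between measured compounds exists to show how a change of this kind has moved the read-out.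

Compound 4 `CS(=O)(=O)Nc1ccc2c(c1)S(=O)(=O)N=C(C1=C(O)C3CCCC3N(Cc3ccccc3)C1=O)N2` differs from compound 1 in one place: hydrogen in place of chloro on an aromatic carbon. The three limits give no reason to expect the read-out to move beyond the usual scatter on going from compound 1 to compound 4, and the most likely outcome is that compound 4 also returns only a limit. The step that the limit leaves unreadable from compound 1 to compound 4 is therefore expected to be essentially none. The estimate for compound 4 on this assay is 15000 nM, within 5000 nM to 50000 nM.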

Compound 4, half-maximal cytotoxic concentration: > 33000 nM
Compound 4 gave a limit, no number; the forecaster's own chance of this, stated with the estimate: 80%; middle value at least 2.2-fold (0.34 log units) away from the limit.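

In this assay compound 1 and compound 4 each gave only a limit of the test, not a number; the size of the change on going from chloro to hydrogen cannot be read from this pair. The compounds shown leave open at what concentration any of them becomes toxic to these cells: none of the four gives a number.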